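The source may hold more compounds than are shown below. What is called first, only, known or untested is meant among the compounds shown, and "the series" means these compounds.

Compounds measured in an assay on isolated protein for inhibition of Aromatase (Homo sapiens), read by fluorescence, with a stated time of 30 min; a lower number here means a stronger inhibitor, a higher number a weaker inhibitor:

Compound 1 `CCC/C(=C(/c1ccc(O)cc1)c1ccc(OCCN)cc1)c1ccccc1` gives 261 nM.
Compound 2 `CC/C(=C(/c1ccc(O)cc1)c1ccc(CCCN)cc1)c1ccccc1` gives 7340 nM.
Compound 3 `CC/C(=C(/c1ccc(O)cc1)c1ccc(CCCN)cc1)c1ccc(O)cc1` gives 491 nM.

Compound 1 holds the lowest of the three numbers in this assay. Compound 3 stands nearest to it, within the scatter of repeated measurements, so the two cannot be ordered; compound 2 stands furthest away, beyond the scatter. Within the data shown here, the only step between two measured compounds that differ in one place is a 15-fold lower number from compound 2 to compound 3 (1.17 log units; beyond the scatter), a hydroxy in place of hydrogen on an aromatic carbon.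

Compound 4 `C/C(=C(/c1ccc(O)cc1)c1ccc(OCCN)cc1)c1ccccc1` differs from compound 1 by hydrogen in place of ethyl on a saturated chain carbon bound to a double-bonded chain carbon. Among the measured compounds shown here, no measured pair probes this chain: the step from compound 2 to compound 3 concerns a different place on the molecule and gives no guide to the chain length, and compounds 1 and 3 differ in more than one place, so their values show only that they sit within the scatter of each other. For the measured compounds named here, with nothing among the measured compounds pointing to a shift, compound 4 is expected to stay close to compound 1. Compound 4 is thus expected to show a 1.1-fold higher number from compound 1 to compound 4 (0.06 log units; within the scatter). Compound 4 is estimated at 300 nM, with a range from 100 nM to 900 nM.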

Compound 4, half-maximal inhibitory concentration: 337 nM
Beside the measured number, compound 4's estimate is 1.1-fold (0.05 log units) below it; low and high end bracket the measured number.
By their numbers in this assay, from the lowest: compounds 1, 4 and 3 (each within the scatter of the next); then compound 2.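

In this assay, among these compounds, the only pair that probes this chain gives a 1.3-fold higher number from compound 1 to compound 4 (0.11 log units; within the scatter) for the change from propyl to methyl, so compound 1 and compound 4 cannot be ordered. The result adds a direct reading at this position: removing 2 carbon heavy atoms from the chain leaves the number within the scatter in this pair, whereas the hydroxy step elsewhere on the molecule gave a 15-fold lower number from compound 2 to compound 3 (1.17 log units; beyond the scatter) and lay beyond it. Nothing available here bears on why the chain change leaves the value where it stands.

On these data alone, the two compounds cover only propyl and methyl on the core of compound 1, so it stays open whether a longer chain such as butyl, a cyclopropyl ring, or a chain ending in a hydroxy or an amine would also stay within the scatter. As far as these compounds go, it also stays open whether the same shortening would read alike on the core of compound 3, which carries a second hydroxy and a different side chain.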